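Side chain change from compound 3 to compound 4

The source may hold more compounds than are shown below. What is called first, only, known or untested is meant among the compounds shown, and "the series" means these compounds.

Measured so far in a physicochemical assay for solubility, at pH 7.4 (a higher number here means a more soluble compound, a lower number a less soluble compound), are three compounds:
- compound 1 `CCCCNc1nc(N)c2nc(O)n(Cc3ccc(OC)nc3)c2n1` gives < 1000 ug/mL as a limit of the assay
- compound 2 `CCCCNc1nc(N)c2[nH]c(=O)n(Cc3ccc(OCCCN(C)C)nc3)c2n1` gives 288000 ug/mL as a number
- compound 3 `CCCCNc1nc(N)c2[nH]c(=O)n(Cc3ccc(N(C)CCCN(C)C)nc3)c2n1` gives 725000 ug/mL as a number

Compound 3 at 725000 ug/mL stands highest of the two numbers. Compound 4 `CCCCNc1nc(N)c2[nH]c(=O)n(Cc3ccc(N4CCC(N(C)C)C4)nc3)c2n1` carries 3-(dimethylamino)pyrrolidin-1-yl in place of (3-(dimethylamino)propyl)(methyl)amino on an aromatic carbon and so gains one five-membered non-aromatic ring. For the measured compounds named here, the only measured step that bears on this change is the modest one, a 2.5-fold higher number from compound 2 to compound 3 (0.40 log units; beyond the scatter) and, with that as the guide, no step beyond the scatter is expected in this assay here. The estimated step is a 1.5-fold lower number from compound 3 to compound 4 (0.16 log units; within the scatter) and its direction is not firm. For compound 4 the estimate is 500000 ug/mL with an expected range of 200000 ug/mL to 1200000 ug/mL in this assay.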

Compound 4, solubility: 53000 ug/mL
For compound 4 the middle estimate is 9.4-fold (0.97 log units) above the measured one, outside the stated range (below it).
By their numbers in this assay, from the lowest: compound 4; then compound 2; then compound 3. At a limit, below all of these: compound 1.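

In this assay the shape of the side chain on this aromatic carbon counts, not only its atoms: 3-(dimethylamino)pyrrolidin-1-yl in place of (3-(dimethylamino)propyl)(methyl)amino, with equal heavy-atom counts, gives a 14-fold lower number from compound 3 to compound 4 (1.14 log units; beyond the scatter) and is a large step. The same ring in place of 3-(dimethylamino)propoxy gives a 5.4-fold lower number from compound 2 to compound 4 (0.74 log units; beyond the scatter) and is a modest step, so both open chains stand above the ring here.

As far as these compounds go, whether a piperazine or a 4-(dimethylamino)piperidine would follow compound 4 or the open chains stays open. Nothing shown accounts for the fall.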